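The source may hold more compounds than are shown below. What is called first, only, known or untested is meant among the compounds shown, and "the series" means these compounds.

Measured so far in a functional assay on the whole organism (strain albino) for inhibition, with Rattus norvegicus as the target, read by paw edema, with a stated time of 2 h, at a dose of 0.28 mmol/kg by the oral route; a higher number here means more inhibition at the dose given (going by the name of the read-out), a lower number less inhibition:

compound 1, `C=CCn1c(SCC(=O)c2ccccc2)nnc1-c1ccccc1`: gives 58%
compound 2, `C=CCn1c(SCC(=O)c2ccccc2)nnc1-c1ccc(OC)c(OC)c1`: gives 63%
compound 3, `C=CCn1c(SC/C(=N/O)c2ccccc2)nnc1-c1ccc(OC)cc1`: gives 66%

Compound 3 carries the highest of the three numbers in this assay, yet its gaps to compound 2 and to compound 1 are both within the scatter, so no order among the three can be read.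

Compound 4, `C=CCn1c(SCC(=O)c2ccccc2)nnc1-c1ccc(OC)cc1`, is not yet measured. Set against compound 3: a group of 8 heavy atoms (7 carbon, 1 oxygen; one six-membered aromatic ring of carbon only) in place of a group of 9 heavy atoms (7 carbon, 1 nitrogen, 1 oxygen; one six-membered aromatic ring of carbon only), on a saturated chain carbon bound to a sulfur. Among the compounds with values here, no step between measured compounds is available for this change. Compound 1 and compound 2 both carry the entering benzoyl and both sit within the scatter of compound 3, so the step from compound 3 to compound 4 is expected to be none beyond the scatter: a number 6 percentage points lower from compound 3 to compound 4 (within the scatter). For compound 4 the estimate in this assay is 60%, in the range 48% to 72%.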

Compound 4, a percentage reported as inhibition, in the whole organism at one dose (the size of the read-out at that dose, not a potency): 53%
Estimate against measurement, compound 4: 7 percentage points above, and the stated range covers the measured number.
By their numbers in this assay, from the lowest: compounds 4, 1, 2 and 3 (each within the scatter of the next, the first and the last beyond it).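

In this assay, within the data shown here, the change at the saturated chain carbon bound to a sulfur gives the first step beyond the scatter: a number 13 percentage points lower from compound 3 to compound 4 (beyond the scatter), with benzoyl entering for the group of 9 heavy atoms. Methoxy against hydrogen on an aromatic carbon gives no such step, with a number 10 percentage points lower from compound 2 to compound 4 (within the scatter) and a number 5 percentage points lower from compound 1 to compound 4 (within the scatter). No measurement at hand bears on why the chain-carbon step arises.

Going by these compounds, whether that step holds with the aromatic substitution of compound 1 or compound 2 stays open, as only compound 3 carries the leaving group. On these data alone, how an amine or a carboxylic acid at this place would read also stays open.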